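The compounds below may be only part of what the source reports. "The series", "measured", "known", "first", "only" and "open" are said of these compounds alone.

Compound 1 `CN(C[C@H]1Cc2c(cccc2N2CCN(C3COC3)CC2)CN1)[C@H]1CCCc2cccnc21`: 725 nm/s
Compound 2 `CN(C[C@H]1Cc2c(cccc2N2CCN3CCC[C@H]3C2)CN1)[C@H]1CCCc2cccnc21`: 167 nm/s
Compound 3 `C[C@@H]1CN(c2cccc3c2C[C@H](CN(C)[C@H]2CCCc4cccnc42)NC3)C[C@H](C)N1C`: 142 nm/s

All three values come from an ADME assay for permeability, using PAMPA, at pH 7.4; on this read-out higher numbers stand for higher permeability and lower numbers for lower permeability. Compound 3 sits at the low end of this small set, a position it shares with compound 2. The data show a 1.2-fold lower number from compound 2 to compound 3 (0.07 log units; within the scatter), while the high end is set apart by a 5.1-fold lower number from compound 1 to compound 3 (0.71 log units; beyond the scatter).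

Compound 4 `CCN1CCN(c2cccc3c2C[C@H](CN(C)[C@H]2CCCc4cccnc42)NC3)CC1` differs from compound 3 in one place: 4-ethylpiperazin-1-yl in place of 3,4,5-trimethylpiperazin-1-yl on an aromatic carbon. Among the compounds with values here, the closest precedent is the exchange of one group free of oxetane for another, which gave a 1.2-fold lower number from compound 2 to compound 3 (0.07 log units; within the scatter). The larger steps, a 4.3-fold lower number from compound 1 to compound 2 (0.64 log units; beyond the scatter) and a 5.1-fold lower number from compound 1 to compound 3 (0.71 log units; beyond the scatter), both involve losing the 4-(oxetan-3-yl)piperazin-1-yl group, and compound 4 lacks that group as well. Within the data shown here, no measured step covers this exact exchange, so the expectation is only tentative. No change beyond the scatter is expected in this assay, and the estimated step is a 1.1-fold lower number from compound 3 to compound 4 (0.02 log units; within the scatter). For compound 4 the estimated value is 135 nm/s, with an expected range of 70 nm/s to 270 nm/s.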

Compound 4, apparent permeability: 205 nm/s
The estimate for compound 4 lay 1.5-fold (0.18 log units) below the measured number; the measured number falls inside the stated range.
By their numbers in this assay, from the lowest: compounds 3, 2 and 4 (each within the scatter of the next); then compound 1.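

With a 1.4-fold higher number from compound 3 to compound 4 (0.16 log units; within the scatter) and a 1.2-fold higher number from compound 2 to compound 4 (0.09 log units; within the scatter), the 4-ethylpiperazin-1-yl group joins the other two groups free of oxetane on this aromatic carbon, so compounds 2, 3 and 4 all read alike in this assay. The pair of compound 1 and compound 4 isolates a single exchange on the amine nitrogen in a ring, ethyl in place of oxetan-3-yl, and it gives a 3.5-fold lower number from compound 1 to compound 4 (0.55 log units; beyond the scatter) with the rest of the structure unchanged. Nothing measured here accounts for this difference.

The compounds shown leave open whether another oxygen-containing ring on that nitrogen, such as tetrahydropyran-4-yl, or an acyl group such as acetyl, would stand with compound 1 or with the other three. They also leave open whether oxetan-3-yl would have the same effect on a different core.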